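A Methyl Group on an Inactive Phenyl Compound

This account rests on a few compounds, and the source may have more. Where it says the series, first, only, none or still open, it means among the compounds named here.

This small series of compounds shares a sugar-bearing core and is tested in a functional assay on MCF7 cells (Homo sapiens) for antiproliferative activity, read by sulforhodamine B assay, with a stated time of 72 h; a lower number here means a stronger inhibitor, a higher number a weaker inhibitor. Compound 1 (`Cc1ccc(N2CCN(c3ncnc4c3ncn4[C@@H]3O[C@H](CO)[C@@H](O)[C@H]3O)CC2)cc1`) gives > 100000 nM, which is a limit of the assay and not a number. Compound 2 (`Nc1nc(N2CCN(c3ncccn3)CC2)c2ncn([C@@H]3O[C@H](CO)[C@@H](O)[C@H]3O)c2n1`) is reported as "not active" (no number reported), with no number given. Compound 3 (`Nc1nc(N2CCN(c3ccccc3)CC2)c2ncn([C@@H]3O[C@H](CO)[C@@H](O)[C@H]3O)c2n1`) is also reported as "not active" (no number reported), so it has no number of its own to serve as a starting point.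

Compound 4 (`Cc1ccc(N2CCN(c3nc(N)nc4c3ncn4[C@@H]3O[C@H](CO)[C@@H](O)[C@H]3O)CC2)cc1`) has not yet been measured. Among the measured compounds shown here, the single structural change is methyl in place of hydrogen on an aromatic carbon, turning phenyl to 4-methylphenyl. For the measured compounds named here, no measured pair shows what a single change of this kind does in this assay.

A change this small is not expected to transform the result, because compound 3 is "not active" (no number reported). The most likely outcome is no step beyond the scatter, with compound 4 staying weak or inactive, and any step that does appear is expected to be a modest one towards stronger inhibition. For compound 4, the estimated half-maximal inhibitory concentration is 60000 nM, with an expected range from 20000 nM to 100000 nM.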

Compound 4, half-maximal inhibitory concentration: "not active" (no number reported)
No number was reported for compound 4, so the estimate cannot be set against anything.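

Among the compounds shown here, compound 3 and compound 4 are both reported as not active in this assay, with no number for either, so no step from the added methyl group can be read. What a single change on the shared core does to activity stays open, and the only figure shown, for compound 1, is a limit and not a number: the limit of > 100000 nM in this assay, at which 1 of the 4 values shown sits.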